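A Smaller Ring on the Thiocarbonyl Carbon

This account rests on a few compounds, and the source may have more. Where it says the series, first, only, none or still open, it means among the compounds named here.

Of the compounds shown here, three have been measured in a functional assay on MCF7 cells (Homo sapiens) for cytotoxicity, read by MTT assay, with a stated time of 72 h; on this read-out higher numbers stand for weaker inhibition and lower numbers for stronger inhibition. Compound 1 `Cc1ccnc(/C(N)=N/NC(=S)N2CCSCC2)c1` gives 6900 nM and compound 3 `Cc1ccnc(/C(N)=N/NC(=S)N2CCCCCC2)c1` gives 6900 nM; both differ from compound 2 in more than one place, so neither isolates a single change against it. Compound 2 `Cc1cccc(/C(N)=N/NC(=S)N2CCCCC2)n1` gives 74000 nM, the highest of the three numbers, and its gaps to compound 1 and to compound 3 both lie beyond the scatter of this assay.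

Compound 4 `Cc1cccc(/C(N)=N/NC(=S)N2CCCC2)n1` is not yet measured. It differs from compound 2 by pyrrolidin-1-yl in place of piperidin-1-yl on a thiocarbonyl carbon. Among the compounds with values here, no measured pair shows what this exchange does on this core, and the other two compounds carry a different core, so nothing in the data anchors the size of the step. Compound 4 is therefore expected to stay close to compound 2, with a step of a 1.2-fold lower number from compound 2 to compound 4 (0.09 log units; within the scatter) that should not go beyond the scatter. The estimate for compound 4 in this assay is 60000 nM, within the range 20000 nM to 150000 nM.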

Compound 4, half-maximal inhibitory concentration: 61800 nM
For compound 4 the middle estimate is 1.0-fold (0.01 log units) below the measured one; low and high end bracket the measured number.
By their numbers in this assay, from the lowest: compounds 1 and 3 (each within the scatter of the next); then compounds 4 and 2 (each within the scatter of the next).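

In this assay, within the data shown here, the exchange of piperidin-1-yl for pyrrolidin-1-yl on a thiocarbonyl carbon gives a 1.2-fold lower number from compound 2 to compound 4 (0.08 log units; within the scatter) and is the only comparison in the set that isolates a single change. On the core shared by compound 2 and compound 4, the six-membered ring at this position can thus give way to the five-membered ring with no shift that stands out from the scatter, so the two rings cannot be told apart on this read-out. Nothing available bears on why the two compounds read alike.

Going by these compounds, whether a morpholine ring or a dimethylamino group at the same place would move the number remains open. So does whether the same exchange of rings would read alike on the core of compound 1.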